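The source may report more compounds than this note shows. Statements on the series, on what has been measured and on what is new or still open speak of the compounds shown alone.

Compound 1 `COc1ccc(N2C(=O)COc3ccc(-c4cnc(Cl)c(NS(=O)(=O)c5ccc(F)cc5)c4)cc32)cc1` and compound 2 `O=C1COc2ccc(-c3cnc(Cl)c(NS(=O)(=O)c4ccc(F)cc4)c3)cc2N1c1ccc(F)cc1` share one core, while compound 3 `COc1ccc(N2C(=O)COc3ccc(-c4cnc5ccccc5c4)cc32)cc1` is built on another; the difference between the two cores is not broken down here. In a functional assay on HCT-116 cells (Homo sapiens) for antiproliferative activity, read by MTT assay, with a stated time of 72 h (a lower number here means a stronger inhibitor, a higher number a weaker inhibitor), compound 1 gives 30100 nM. In this assay compound 2 gives 34200 nM. The change between them is fluoro in place of methoxy on an aromatic carbon, and it produced a 1.1-fold higher number from compound 1 to compound 2 (0.06 log units; within the scatter). For compound 3, this assay reports only a limit, > 40000 nM, and this is the limit of > 40000 nM in this assay, at which 1 of the 3 values shown sits. Compound 4 `O=C1COc2ccc(-c3cnc4ccccc4c3)cc2N1c1ccc(F)cc1` has not yet been measured. Going by the values given here, it differs from compound 3 by fluoro in place of methoxy on an aromatic carbon, the same change as the one between compound 1 and compound 2, made at the same place on the ring. Since that earlier change left the number essentially where it was, the expected step here is a step that the limit leaves unreadable from compound 3 to compound 4, which rests on the measured 1.1-fold higher number from compound 1 to compound 2 (0.06 log units; within the scatter). Compound 4 is therefore estimated to give 50000 nM in this assay, plausibly between 28000 nM and 100000 nM, and most likely the assay will again report only a limit.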

Compound 4, half-maximal inhibitory concentration: > 40000 nM
Compound 4 was reported as a limit; the forecaster's own chance of this, stated with the estimate: 80%; the middle value is on the limit's open side.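

In this assay, compound 3 and compound 4 are both reported only as limits, and no step can be read between them: the limit of > 40000 nM in this assay, at which 2 of the 4 values shown sit.

The compounds shown leave open what number either compound would give, and whether fluoro in place of methoxy matters on the core of compound 3 as little as it did between compound 1 and compound 2.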